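Trifluoromethyl to Fluoro: Can a Cytotoxicity Step Repeat?

A few compounds are considered here, and "the series" means these few. Any claim that something is new, unique, unknown or untested is made for them only; others in the source may bear on it.

Compound 1 `O=C(Nc1cccc(C(F)(F)F)c1)c1cc(Cl)ccc1O` and compound 2 `O=C(Nc1ccc(C(F)(F)F)cc1)c1cc(Cl)ccc1O` are built from the same atoms joined differently; the difference between the two cores is not broken down here. In an ADME assay on cells (Macrophage, Mus musculus) for cytotoxicity, read by resazurin assay, with a stated time of 3 days (a lower number here means a stronger inhibitor, a higher number a weaker inhibitor), compound 1 gives 5900 nM, while compound 2 gives 2800 nM, the lowest of the three measured numbers. Compound 3 `O=C(Nc1cccc(F)c1)c1cc(Cl)ccc1O`, in this assay, gives 15000 nM. Its change from compound 1 is fluoro in place of trifluoromethyl on an aromatic carbon, and that change produced a 2.5-fold higher number from compound 1 to compound 3 (0.41 log units; beyond the scatter). Compound 4 `O=C(Nc1ccc(F)cc1)c1cc(Cl)ccc1O` carries the same kind of change from compound 2, (fluoro in place of trifluoromethyl on an aromatic carbon), though the place differs: para to a large group rather than meta to a large group. A similar weakening is expected because the earlier step was a 2.5-fold higher number from compound 1 to compound 3 (0.41 log units; beyond the scatter). Compound 4 is therefore estimated at 7000 nM in this assay, likely between 3500 nM and 14000 nM. That estimate means an expected step of a 2.5-fold higher number from compound 2 to compound 4 (0.40 log units; beyond the scatter).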

Compound 4, half-maximal inhibitory concentration: 17000 nM
Compound 4: middle estimate off by 2.4-fold (0.39 log units), on the low side; measured number above the stated range.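

In this assay, replacing trifluoromethyl with fluoro gives a 6.1-fold higher number from compound 2 to compound 4 (0.78 log units; beyond the scatter) on this second core. The change therefore raises the number on both cores, and the two steps cannot be told apart in size: the same change on two cores in this assay, a 2.5-fold higher number (0.41 log units; beyond the scatter) from compound 1 to compound 3 and a 6.1-fold higher number (0.78 log units; beyond the scatter) from compound 2 to compound 4, 2.4-fold (0.38 log units) apart, within the scatter of two such steps. Among these compounds, with only two pairs, this shows that the direction carried over, but it does not fix a reliable size for the step or explain why the number rises.

On these data alone, it remains open whether the same rise would follow if trifluoromethyl gave way to another group, such as a nitrile or a methoxy group. As far as these compounds go, it is also open whether the pattern would hold on a core changed elsewhere, for example with an amine in place of the chloro group.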